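The compounds below may be only part of what the source reports. "The series", "measured", "known", "first", "only" and "open" are said of these compounds alone.

Measured so far:
- compound 1 `Nc1ccccc1NC(=O)c1ccc(NC(=S)NCc2cccnc2)cc1` gives 116 nM in an assay on isolated protein for inhibition of Nicotinamide phosphoribosyltransferase (Homo sapiens), read by fluorescence, with stated times of 5 min and 15 min; a higher number here means a weaker inhibitor, a lower number a stronger inhibitor
- compound 2 `Nc1ccccc1NC(=O)c1ccc(NC(=O)NCc2cccnc2)cc1` gives 550 nM in this assay

Compound 2 carries the higher of the two numbers, and its gap to compound 1 lies beyond the scatter. Compound 3 `Nc1ccccc1NC(=O)c1ccc(NC(=O)NCc2ccc(F)nc2)cc1` follows from compound 2 by fluoro in place of hydrogen on an aromatic carbon. Within the data shown here, no measured pair shows this change, so nothing here tells how large a step to expect. Compound 3 is expected to stay close to compound 2, with a step of a 1.1-fold lower number from compound 2 to compound 3 (0.04 log units; within the scatter) in this assay, not beyond the scatter in either direction. Compound 3 is estimated at 500 nM, within 200 nM to 1300 nM.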

Compound 3, half-maximal inhibitory concentration: > 2000 nM
Compound 3 was reported as a limit; the forecaster's own chance of this, stated with the estimate: 3%; middle value at least 4.0-fold (0.60 log units) away from the limit.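

Replacing pyridin-3-yl with 6-fluoropyridin-3-yl adds only 1 heavy atom, yet in this assay it gives an at least 3.6-fold higher number from compound 2 to compound 3 (0.56 log units; beyond the scatter). Among these compounds, this is the first sign that the ring carbon next to the ring nitrogen is sensitive to substitution, at least in this single pair. The value of compound 3 is a limit, so the full size of the loss stays unknown: the limit of > 2000 nM in this assay, at which 1 of the 3 values shown sits.

The compounds shown leave open whether a chloro, methyl or amine at this carbon would also weaken inhibition. They also leave open whether fluoro would have the same effect on the core of compound 1.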